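Methoxy removal at the chain carbon of compound 1

A few compounds are considered here, and "the series" means these few. Any claim that something is new, unique, unknown or untested is made for them only; others in the source may bear on it.

Measured so far:
compound 1 `COCC(C(=O)N1CCN(c2cccc(C(F)(F)F)c2)CC1)N1C(=O)CCC1=O` — 75%
compound 2 `CCC(C(=O)N1CCN(c2ccccc2F)CC1)N1C(=O)CCC1=O` — 0%
compound 3 `CCC(C(=O)N1CCN(c2cccc(C)c2)CC1)N1C(=O)CCC1=O` — 0%

In a functional assay on the whole organism (strain Swiss) with Mus musculus as the target, in the maximal electroshock model, with a stated time of 0.5 h, at a dose of 100 mg/kg by the intraperitoneal route (on this read-out higher numbers stand for a stronger effect at the one dose given and lower numbers for a weaker effect), compound 1 gives the highest of the three numbers; compound 2 and compound 3 both stand far below it, beyond the scatter. Going by the values given here, the single measured step, no change at the digits printed from compound 2 to compound 3 (within the scatter), concerns the aryl group on the ring nitrogen and says nothing about the chain. Compound 4 `CC(C(=O)N1CCN(c2cccc(C(F)(F)F)c2)CC1)N1C(=O)CCC1=O` differs from compound 1 by hydrogen in place of methoxy on a saturated chain carbon, two bonds along the chain from an amide-type nitrogen in a ring and a carbonyl carbon. Among the compounds with values here, no measured step addresses this change. Compound 2 and compound 3 carry ethyl at the saturated chain carbon, yet they also carry a different aryl group, so their values cannot be tied to the chain alone. A moderate drop is expected, a number 25 percentage points lower from compound 1 to compound 4 (beyond the scatter), with wide uncertainty. For compound 4 the expected activity is 50%, within 10% to 90%.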

Compound 4, a percentage reported as activity, at one dose (the size of the read-out at that dose, not a potency): 75%
Estimate against measurement, compound 4: 25 percentage points below; low and high end bracket the measured number.
By their numbers in this assay, from the lowest: compounds 2 and 3 (each within the scatter of the next); then compounds 1 and 4 (each within the scatter of the next).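

Hydrogen in place of methoxy on this saturated chain carbon gives no change at the digits printed from compound 1 to compound 4 (within the scatter) in this assay and is the first measured step at this position. With the aryl group held constant, the methoxymethyl to methyl difference therefore leaves the read-out in place at this one dose, so the methoxy group is not required for activity here. No available evidence bears on this result.

Going by these compounds, whether an amine, a carboxylic acid or a longer chain at this carbon would hold the read-out stays open. Ethyl with the aryl group of compound 1 is also open, as compound 2 and compound 3 carry ethyl only with other aryl groups.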